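Piperidin-1-yl replaces propylsulfanyl on the shared core

The source may hold more compounds than are shown below. What is called first, only, known or untested is meant among the compounds shown, and "the series" means these compounds.

In a functional assay on the whole organism with Mus musculus as the target (on this read-out lower numbers stand for an effect already at smaller amounts and higher numbers for an effect only at larger amounts of compound), compound 1 (`Cc1c(C)c2c(c(C)c1N)CC(C)(CSc1nccn1C)O2`) gives 37.1 mg/kg, compound 2 (`Cc1c(C)c2c(c(C)c1N)CC(C)(CSCc1ccccc1)O2`) gives 32 mg/kg and compound 3 (`CCCSCC1(C)Cc2c(C)c(N)c(C)c(C)c2O1`) gives 24.6 mg/kg. Compound 3 therefore stands within the scatter of both other compounds. Compound 4 (`Cc1c(C)c2c(c(C)c1N)CC(C)(CN1CCCCC1)O2`) carries piperidin-1-yl in place of propylsulfanyl on a saturated chain carbon bound to a saturated ring carbon.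

The measured steps that bear on this change only exchange the group on the sulfur: a 1.2-fold lower number from compound 1 to compound 2 (0.06 log units; within the scatter), a 1.5-fold lower number from compound 1 to compound 3 (0.18 log units; within the scatter) and a 1.3-fold lower number from compound 2 to compound 3 (0.11 log units; within the scatter). All of them lie within the scatter. None of them removes the sulfur, so the data cover this change only indirectly, and the expectation remains uncertain. With that caution, no shift beyond the scatter is expected in this assay, and the estimated step is a 1.2-fold higher number from compound 3 to compound 4 (0.09 log units; within the scatter). For compound 4 the expected value is 30 mg/kg, with an estimated range from 13 mg/kg to 65 mg/kg.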

Compound 4, dose for 50% inhibition: 11.7 mg/kg
For compound 4 the middle estimate is 2.6-fold (0.41 log units) above the measured one, and the stated range ends above it.
By their numbers in this assay, from the lowest: compound 4; then compounds 3, 2 and 1 (each within the scatter of the next).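

Earlier exchanges of the group on the sulfur left the numbers within the scatter of one another, so this position had looked insensitive in this assay. Replacing the whole sulfur-linked group with piperidin-1-yl on the saturated chain carbon bound to a saturated ring carbon shows otherwise, giving a 2.1-fold lower number from compound 3 to compound 4 (0.32 log units; beyond the scatter) and, against the (1-methyl-1H-imidazol-2-yl)sulfanyl group, a 3.2-fold lower number from compound 1 to compound 4 (0.50 log units; beyond the scatter) in the same direction. Nothing shown here explains why this change lowers the number.

The compounds shown do not separate the contribution of the ring from that of the nitrogen taking the place of the sulfur. From the compounds shown here alone, whether an open-chain amine such as diethylamino, or a morpholin-4-yl ring, on the same carbon would keep the lower number remains open.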